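Hydroxy in place of methylsulfanyl on an inactive core

The compounds below may be only part of what the source reports. "The series", "measured", "known", "first", "only" and "open" are said of these compounds alone.

Compound 1 `CCCc1nnc(SC)n2c(CCC)nc(C)c12` gives only a limit, > 48000 nM, in a functional assay for inhibition, with Homo sapiens as the target; on this read-out lower numbers stand for stronger inhibition and higher numbers for weaker inhibition.
Compound 2 `CCCc1nc(C)c2c(C)nnc(SC)n12` gives only a limit, > 48000 nM, in this assay.
Compound 3 `CSc1nnc(C)c2c(C)nc(C)n12` gives only a limit, > 48000 nM, in this assay.

Compound 2 therefore stands at the same limit as the other two measured compounds, and no number for it is known. The two steps that touch it, a step that the two limits leave unreadable from compound 1 to compound 2 and a step that the two limits leave unreadable from compound 2 to compound 3, cannot be read in size or direction because of the limit of > 48000 nM in this assay, at which 3 of the 3 values shown sit. Compound 4 `CCCc1nc(C)c2c(C)nnc(O)n12` differs from compound 2 in one place: hydroxy in place of methylsulfanyl on an aromatic carbon. For the measured compounds named here, no measured step resembles this exchange, and the steps that exist give no guidance, so there is no basis for expecting any readable movement in this assay. The most likely outcome is that compound 4 again gives only a limit. As a placeholder estimate, compound 4 is expected at 100000 nM, with a range from 30000 nM to 500000 nM. The estimated step that the limit leaves unreadable from compound 2 to compound 4 is thus expected to be unreadable rather than a real change.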

Compound 4, half-maximal inhibitory concentration: 14000 nM
Beside the measured number, compound 4's estimate is 7.1-fold (0.85 log units) above it; measured number below the stated range.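

In this assay, replacing methylsulfanyl with hydroxy gives an at least 3.4-fold lower number from compound 2 to compound 4 (0.53 log units; beyond the scatter), and compound 4 is the only compound shown with a readable number. For the compounds shown here, the aromatic carbon between two ring nitrogen atoms is therefore a place where a single exchange can move the read-out, which the earlier compounds, with no readable step among them, could not show. The true size of this step remains unknown because compound 2 has no number, only a limit: the limit of > 48000 nM in this assay, at which 3 of the 4 values shown sit.

The compounds shown do not reveal whether the hydrogen-bond donor that hydroxy brings or the smaller size of the group matters more. They also leave open how an amine or a methoxy group would read on this carbon, and whether hydroxy would give a readable number on the core of compound 1 or compound 3.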